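A few compounds are considered here, and "the series" means these few. Any claim that something is new, unique, unknown or untested is made for them only; others in the source may bear on it.

Measured compounds in the series:

- Compound 1, `COc1ccc2cc(C(C)c3nnc4n3N=C(c3ccc([N+](=O)[O-])cc3)CS4)ccc2c1`: 14700 nM
- Compound 2, `CC(c1ccc(-c2ccccc2)c(F)c1)c1nnc2n1N=C(c1ccc(OC(F)(F)F)cc1)CS2`: 8400 nM

For the measured compounds named here, in a functional assay on Huh-7 cells (Homo sapiens) for inhibition, read by sulforhodamine B assay, with a stated time of 72 h (on this read-out lower numbers stand for stronger inhibition and higher numbers for weaker inhibition), compound 2 gives 8400 nM, the lower of the two numbers so far; compound 1 gives 14700 nM, and the gap between the two lies within the scatter, so neither compound can be called the stronger inhibitor.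

The next compound, compound 3 with structure `CC(c1ccc(-c2ccccc2)c(F)c1)c1nnc2n1N=C(c1ccc(Br)cc1)CS2`, differs from compound 2 in one place: bromo in place of trifluoromethoxy on an aromatic carbon, para to a large group. Going by the values given here, no pair of measured compounds shows this change, so its size in this assay is not known from the series. For compound 3 the step of a 1.1-fold lower number from compound 2 to compound 3 (0.02 log units; within the scatter) is expected to stay within the scatter, with no clear direction. Compound 3 is therefore estimated at 8000 nM in this assay, with a range from 3000 nM to 22000 nM.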

Compound 3, half-maximal inhibitory concentration: 5000 nM
Compound 3: middle estimate off by 1.6-fold (0.20 log units), on the high side; measured number inside the range.
By their numbers in this assay, from the lowest: compounds 3, 2 and 1 (each within the scatter of the next, the first and the last beyond it).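

In this assay, for the compounds shown here, the 4-(trifluoromethoxy)phenyl to 4-bromophenyl change gives a 1.7-fold lower number from compound 2 to compound 3 (0.23 log units; within the scatter) and is the first step that can be read at a single place. At this position, para to a large group, trifluoromethoxy and bromo cannot be told apart on this read-out. The exchange of these two groups therefore leaves the number within the scatter, in this one pair only.

Still open, going by these compounds, is whether another group at this position, such as an amine or a carboxylic acid, would give a step beyond the scatter. Also open, on these data alone, is whether the same exchange would read alike on a different left-hand part, such as that of compound 1. No measurement at hand bears on the reason for this result.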